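Changing the Aryl Ring on a Scaffold Without Measured Activity

The compounds below may be only part of what the source reports. "The series", "measured", "known", "first", "only" and "open" are said of these compounds alone.

The measured compounds and their values:
compound 1, `C=CC1=C(C(=O)O)C(c2ccc(OC)cc2)OC1`, in a functional assay on QGY7701 cells (Homo sapiens) for cytotoxicity, read by MTT assay, with a stated time of 24 h (a higher number here means a weaker inhibitor, a lower number a stronger inhibitor), gives > 100000 nM.
compound 2, `C=CC1=C(C(=O)NCC(C)C)C(c2ccc(Cl)c(Cl)c2)OC1`, in this assay gives > 100000 nM.
compound 3, `C=CC1=C(C(=O)Nc2ccccc2)C(c2ccc(Cl)c(Cl)c2)OC1`, in this assay gives > 100000 nM.

Each of these three values is a limit of this assay, not a number: the cells were not inhibited strongly enough for a concentration to be read, as summed up in the limit of > 100000 nM in this assay, at which 3 of the 3 values shown sit. Compound 3 therefore stands at the limit, and nothing distinguishes it from the other two on the numbers shown. Among the compounds with values here, the only step between measured compounds, a step that the two limits leave unreadable from compound 2 to compound 3, is unreadable, since both ends are limits.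

Compound 4, `C=CC1=C(C(=O)Nc2ccccc2)C(c2ccc(OC)cc2)OC1`, differs from compound 3 by 4-methoxyphenyl in place of 3,4-dichlorophenyl on a saturated ring carbon. Within the data shown here, no measured step follows this swap directly. Compound 1 carries the same 4-methoxyphenyl group and also sits at the limit, so the group on its own has not produced a readable number anywhere in this set. Compound 4 is therefore expected to remain at or beyond the limit, with the step from compound 3 to compound 4 estimated as a step that the limit leaves unreadable from compound 3 to compound 4. The estimate for compound 4 in this assay is 150000 nM, in a range from 40000 nM to 1000000 nM.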

Compound 4, half-maximal inhibitory concentration: > 100000 nM
Compound 4 was reported as a limit (the forecaster's own chance of this, stated with the estimate: 85%); the middle value lies beyond the limit too.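

Within the data shown here, compound 4 gives only a limit in this assay and so do compound 1 and compound 3, so no step from either of them to compound 4 can be read: the limit of > 100000 nM in this assay, at which 4 of the 4 values shown sit. The compounds shown leave open whether any change to the shared core gives a readable value in this assay and how these groups would then rank.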